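Fluoro in Place of Bromo: Another Limit Expected

The source may report more compounds than this note shows. Statements on the series, on what has been measured and on what is new or still open speak of the compounds shown alone.

Compound 1 `Cc1cc(Nc2cccc(S(F)(F)(F)(F)F)c2)nc(N)n1` and compound 2 `Cc1cc(Nc2cccc(Br)c2)nc(N)n1` share one core and differ only at a single aromatic carbon. In an assay on cells for inhibition of S-adenosylmethionine decarboxylase proenzyme (Homo sapiens), read by mass spectrometry, at pH 7.2 (a lower number here means a stronger inhibitor, a higher number a weaker inhibitor), compound 1 gives > 180000 nM, which is a limit of the assay rather than a number. Compound 2 likewise gives > 180000 nM in this assay, again a limit. For the measured compounds named here, the one measured step, a step that the two limits leave unreadable from compound 1 to compound 2, therefore cannot be read, since (the limit of > 180000 nM in this assay, at which 2 of the 2 values shown sit). Compound 2 thus stands at the limit, with no measured number to place it. Compound 3 `Cc1cc(Nc2cccc(F)c2)nc(N)n1` arises from compound 2 by fluoro in place of bromo on an aromatic carbon. No readable measured step bears on this change, so there is no ground to expect compound 3 to move out of the limit in either direction. Compound 3 is expected to give 250000 nM, with a range from 90000 nM to 1000000 nM. The step that the limit leaves unreadable from compound 2 to compound 3 is thus expected to be none beyond the scatter, most likely reported once more as a limit.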

Compound 3, half-maximal inhibitory concentration: > 180000 nM
Compound 3: no number, only a limit (the forecaster's own chance of this, stated with the estimate: 85%); the middle value lies beyond the limit too.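

In this assay, for the compounds shown here, compound 3 gives > 180000 nM, again a limit and not a number, so no step among compound 1, compound 2 and compound 3 can be read: the limit of > 180000 nM in this assay, at which 3 of the 3 values shown sit. The compounds shown leave open how bromo, fluoro and the group of 6 heavy atoms rank against one another on this aromatic carbon.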